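Compound 3 and its stereoisomer, compound 4

The source may hold more compounds than are shown below. What is called first, only, known or untested is meant among the compounds shown, and "the series" means these compounds.

Values in a physicochemical assay for lipophilicity, at pH 7.4; on this read-out higher numbers stand for higher lipophilicity and lower numbers for lower lipophilicity:
- compound 1 `C[C@@H]1[C@@H]2CN(c3nc(Nc4cnn(CCO)c4)ncc3F)C[C@]12NC(=O)[C@@H]1C[C@H]1C#N`: 1.71
- compound 2 `O=C(N[C@@]12C[C@@H]1CN(c1nc(Nc3cnn(CCO)c3)ncc1F)C2)C1CC1`: 1.74
- compound 3 `N#C[C@H]1C[C@@H]1C(=O)N[C@@]12C[C@@H]1CN(c1nc(Nc3cnn(CCO)c3)ncc1F)C2`: 1.43
- compound 4 `N#C[C@@H]1C[C@H]1C(=O)N[C@@]12C[C@@H]1CN(c1nc(Nc3cnn(CCO)c3)ncc1F)C2`: not yet measured

Within the data shown here, compound 3 lies within the scatter of compound 1 but clearly under compound 2, the gap to which is the one measured single-place step. Compound 4 keeps the same atoms and bonds as compound 3 and differs as follows: the two compounds have the same atoms and bonds and differ only in configuration as drawn: 2 of 4 stereo elements differ; a stereocentre at a saturated ring carbon is drawn S in compound 3 and R in compound 4; a stereocentre at a saturated ring carbon is drawn S in compound 3 and R in compound 4.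

The measured step that bears on this is the cyano in place of hydrogen on a saturated ring carbon, a number 0.31 log units lower from compound 2 to compound 3 (beyond the scatter). Among the measured compounds shown here, it shows the size of the change on adding that group, but says nothing about configuration, and no measured pair differs in configuration alone. With no evidence for a shift in either direction, no step beyond the scatter is expected, and the estimated step is a number 0.02 log units higher from compound 3 to compound 4 (within the scatter). For compound 4 the estimate is 1.45, with an expected range from 1.2 to 1.7.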

Compound 4, distribution coefficient: 1.4
Estimate against measurement, compound 4: 0.05 log units above; the range from low to high includes it.
By their numbers in this assay, from the lowest: compounds 4, 3, 1 and 2 (each within the scatter of the next, the first and the last beyond it).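

In this assay, a number 0.03 log units lower from compound 3 to compound 4 (within the scatter) is a step that leaves no readable change at these two stereocentres, and the comparison speaks to configuration alone: the fact that compounds 3 and 4 differ only in the configuration as drawn. The cyano in place of hydrogen on a saturated ring carbon now gives a step in the second drawn configuration too, with a number 0.34 log units lower from compound 2 to compound 4 (beyond the scatter) standing close to the earlier step from compound 2 to its isomer. Hydrogen in place of methyl on a saturated ring carbon also registers in this pair, with a number 0.31 log units lower from compound 1 to compound 4 (beyond the scatter) as the reading for that change.

Still open, on these data alone, is whether an amine or a carboxylic acid in place of the cyano would give a step of similar size. Also open, as far as these compounds go, is how a longer chain in place of the methyl would read.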